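Methylsulfanyl for benzylselanyl on a thiophene amidine core

The compounds below may be only part of what the source reports. "The series", "measured", "known", "first", "only" and "open" are said of these compounds alone.

Measured compounds in a functional assay on PC-3 cells (Homo sapiens) for cytotoxicity, read by MTT assay, with a stated time of 72 h; a higher number here means a weaker inhibitor of growth, a lower number a stronger inhibitor of growth:
Compound 1 `CS/C(=N\C(=O)c1ccno1)NC(=O)c1ccno1` gives 99200 nM
Compound 2 `O=C(/N=C(/NC(=O)c1ccno1)[Se]Cc1ccccc1)c1ccno1` gives 53100 nM
Compound 3 `O=C(/N=C(/NC(=O)c1cccs1)[Se]Cc1ccccc1)c1cccs1` gives 49900 nM

Compound 1 and compound 2 share a core and differ in one place: a group of 2 heavy atoms (1 carbon, 1 sulfur; no ring) in place of a group of 8 heavy atoms (7 carbon, 1 selenium; one six-membered aromatic ring of carbon only), on a carbon with a double bond to nitrogen. This change gave a 1.9-fold higher number from compound 2 to compound 1 (0.27 log units; within the scatter), a step that lies within the scatter. Compound 3 carries a different core; the difference between the core of compound 2 and the core of compound 3 is not broken down here, and their two values in this assay are within the scatter of each other.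

Compound 4 `CS/C(=N\C(=O)c1cccs1)NC(=O)c1cccs1` has not yet been measured. It stands to compound 3 as compound 1 stands to compound 2: a group of 2 heavy atoms (1 carbon, 1 sulfur; no ring) in place of a group of 8 heavy atoms (7 carbon, 1 selenium; one six-membered aromatic ring of carbon only), on a carbon with a double bond to nitrogen, the same change at the same place. Because the earlier step was a 1.9-fold higher number from compound 2 to compound 1 (0.27 log units; within the scatter), the step from compound 3 to compound 4 is expected to be of similar size, a 1.9-fold higher number from compound 3 to compound 4 (0.28 log units; within the scatter), which rests on a single earlier pair only. Compound 4 is therefore estimated at 95000 nM, with a range from 45000 nM to 200000 nM.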

Compound 4, concentration for 50% growth inhibition: 39000 nM
Beside the measured number, compound 4's estimate is 2.4-fold (0.39 log units) above it; measured number outside the range, below it.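

In this assay, putting methylsulfanyl in place of benzylselanyl on the carbon with a double bond to nitrogen gave a 1.3-fold lower number from compound 3 to compound 4 (0.11 log units; within the scatter). Set beside the same change on the other core, the two steps point in opposite directions, yet they do not differ by more than such steps can: the same change on two cores in this assay, a 1.9-fold higher number (0.27 log units; within the scatter) from compound 2 to compound 1 and a 1.3-fold lower number (0.11 log units; within the scatter) from compound 3 to compound 4, 2.4-fold (0.38 log units) apart, within the scatter of two such steps. This shows that the change stayed within the scatter on both cores, but it does not show that the change has a real effect in either direction, or that its outcome depends on the core.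

The compounds shown change the selenium and the rest of the group together, so a benzylsulfanyl or a methylselanyl group on either core would be needed to tell those two parts apart. Going by these compounds, it also remains open whether a different group at this carbon, such as an amine or a longer alkylsulfanyl chain, would move the number beyond the scatter.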